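Replacing the Methoxy of Compound 1 with a Cyano Group

This account rests on a few compounds, and the source may have more. Where it says the series, first, only, none or still open, it means among the compounds named here.

Among the measured compounds shown here, in a functional assay on OVCAR-3 cells (Homo sapiens) for inhibition, read by MTT assay, with a stated time of 24 h (on this read-out lower numbers stand for stronger inhibition and higher numbers for weaker inhibition), compound 1 `COc1ccc(-n2cc(CN3C(=O)C[C@@H]4CC[C@@]3(C)C4(C)C)nn2)cc1` gives 250 nM, the highest number among the three compounds measured so far. Compound 2 `CC1(C)[C@H]2CC[C@]1(C)N(Cc1cn(-c3ccccc3Br)nn1)C(=O)C2` gives 140 nM in this assay, and compound 3 `CC1(C)[C@H]2CC[C@]1(C)N(Cc1cn(-c3ccccc3Cl)nn1)C(=O)C2` gives 40 nM. The measured steps of a 1.8-fold lower number from compound 1 to compound 2 (0.25 log units; within the scatter), a 6.3-fold lower number from compound 1 to compound 3 (0.80 log units; beyond the scatter) and a 3.5-fold lower number from compound 2 to compound 3 (0.54 log units; beyond the scatter) all exchange the aryl group on the aromatic nitrogen of the shared core, and the two larger ones favour 2-chlorophenyl over the other two aryl groups.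

Compound 4 `CC1(C)[C@H]2CC[C@]1(C)N(Cc1cn(-c3ccc(C#N)cc3)nn1)C(=O)C2` differs from compound 1 as follows: cyano in place of methoxy on an aromatic carbon. For the measured compounds named here, no measured pair exchanges one group at this place for another, so the three steps bear on the change only loosely: they show that changing the aryl group moves the number by a modest amount at most. Compound 4 is therefore expected to give 180 nM in this assay, with a range from 60 nM to 500 nM. That estimate corresponds to an expected step of a 1.4-fold lower number from compound 1 to compound 4 (0.14 log units; within the scatter), one that would stay within the scatter.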

Compound 4, half-maximal inhibitory concentration: 380 nM
Beside the measured number, compound 4's estimate is 2.1-fold (0.32 log units) below it; the range from low to high includes it.
By their numbers in this assay, from the lowest: compound 3; then compounds 2, 1 and 4 (each within the scatter of the next, the first and the last beyond it).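

Among the compounds shown here, the first direct exchange at this aromatic carbon, para to a large group, gives a 1.5-fold higher number from compound 1 to compound 4 (0.18 log units; within the scatter) in this assay, so cyano and methoxy cannot be told apart here. The 4-cyanophenyl group nevertheless stands clearly apart from both halogenated aryl groups, with a 9.5-fold higher number from compound 3 to compound 4 (0.98 log units; beyond the scatter) and a 2.7-fold higher number from compound 2 to compound 4 (0.43 log units; beyond the scatter), although compound 2 itself lies within the scatter of compound 1. Nothing available here accounts for these differences.

Going by these compounds, whether an amine or a carboxylic acid on this aromatic carbon would also stay within the scatter of compound 1 remains open. On these data alone, it is also open whether chloro on this same aromatic carbon would match the number of compound 3, since the aryl groups compared so far differ in both the group and where it sits.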